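A few compounds are considered here, and "the series" means these few. Any claim that something is new, unique, unknown or untested is made for them only; others in the source may bear on it.

Measured so far:
- compound 1, `COC(=O)C1=C(C)N=C(C)/C(=C(\O)OC)C1c1cc([N+](=O)[O-])ccc1O`, 100 nM
- compound 2, `COC(=O)C1=C(C)N=C(C)/C(=C(\O)OC)C1c1cccc(N)c1`, 2000 nM
- compound 3, `COC(=O)C1=C(C)N=C(C)/C(=C(\O)OC)C1c1cccc(I)c1`, 41.7 nM

In a functional assay (muscle tissue) with Cavia porcellus as the target (on this read-out higher numbers stand for an effect only at larger amounts of compound and lower numbers for an effect already at smaller amounts), compound 3 gives the lowest number of the three; compound 1 lies closest to it, and compound 2 lies furthest away. The one step among these compounds that differs in a single place is a 48-fold lower number from compound 2 to compound 3 (1.68 log units; beyond the scatter), the change of iodo in place of amino on an aromatic carbon.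

Compound 4, `COC(=O)C1=C(C)N=C(C)/C(=C(\O)OC)C1c1cccc([N+](=O)[O-])c1`, has not yet been measured. It differs from compound 3 by nitro in place of iodo on an aromatic carbon, placed on an aromatic carbon of a six-membered aromatic ring of carbon only, meta to a large group.

Among the compounds with values here, no measured step covers nitro in place of iodo directly. The step from compound 2 to compound 3 bears only loosely on it, since it swaps a different group for iodo. Compound 1 also carries a nitro group, yet it differs from compound 4 in a second place as well, so its value only shows that a nitro-bearing compound can reach a low number in this assay. Taken together, compound 4 is expected to land near compound 3, with a step of about a 1.0-fold lower number from compound 3 to compound 4 (0.02 log units; within the scatter) that may not exceed the scatter. The estimated value for compound 4 is 40 nM, within a range from 10 nM to 160 nM.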

Compound 4, half-maximal effective concentration: 3.98 nM
Compound 4: middle estimate off by 10-fold (1.00 log units), on the high side; measured number below the stated range.
By their numbers in this assay, from the lowest: compound 4; then compound 3; then compound 1; then compound 2.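

In this assay, the group on this aromatic carbon, meta to a large group, clearly matters: nitro in place of iodo gives a 10-fold lower number from compound 3 to compound 4 (1.02 log units; beyond the scatter) and nitro in place of amino gives a 500-fold lower number from compound 2 to compound 4 (2.70 log units; beyond the scatter), which orders these three groups with nitro lowest, iodo next and amino highest. Iodo was the best of the groups compared here at this position until now, so the lead it held over amino does not mark the limit for this position. Nitro alone does not settle the number, though: hydrogen in place of hydroxy on an aromatic carbon gives a 25-fold lower number from compound 1 to compound 4 (1.40 log units; beyond the scatter), so a second change on the same ring also shifts the result strongly, and no measurement offered here explains either effect.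

The compounds shown leave open where other groups, such as chloro, methyl, nitrile or a carboxylic acid, would fall relative to nitro and iodo on this carbon. They also leave open whether nitro would give a similar number on a different carbon of the ring.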